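The source may report more compounds than this note shows. Statements on the series, on what has been measured and on what is new or still open speak of the compounds shown alone.

Measured compounds:
compound 1 `N#CCC1=NN=C(c2ccc(Br)cc2)C(CC(=O)c2ccc(Br)cc2)O1`: 22100 nM
compound 2 `N#CCC1=C(C#N)CC(c2ccc([N+](=O)[O-])cc2)=C(CC(=O)c2ccc([N+](=O)[O-])cc2)O1`: 80 nM
compound 3 `N#CCC1=NN=C(c2ccc([N+](=O)[O-])cc2)C(CC(=O)c2ccc(Br)cc2)O1`: 40000 nM

In a functional assay on NCI-H460 cells (Homo sapiens) for inhibition, read by sulforhodamine B assay, with a stated time of 48 h (a lower number here means a stronger inhibitor of growth, a higher number a weaker inhibitor of growth), compound 2 gives the lowest number of the three, with its steps to compound 1 and compound 3 both beyond the scatter. The difference between the core of compound 2 and the core of compound 3 is not broken down here. Between compound 3 and compound 1 the change is bromo in place of nitro on an aromatic carbon, and the step it made was a 1.8-fold lower number from compound 3 to compound 1 (0.26 log units; within the scatter).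

Compound 4 `N#CCC1=C(C#N)CC(c2ccc(Br)cc2)=C(CC(=O)c2ccc([N+](=O)[O-])cc2)O1` is not yet measured in this assay. It differs from compound 2 by bromo in place of nitro on an aromatic carbon, the same change as between compound 3 and compound 1. The step expected from compound 2 to compound 4 is a 1.1-fold lower number from compound 2 to compound 4 (0.06 log units; within the scatter), resting on the earlier step of a 1.8-fold lower number from compound 3 to compound 1 (0.26 log units; within the scatter), which lay within the scatter. For compound 4 the estimate in this assay is 70 nM, expected to fall between 25 nM and 200 nM.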

Compound 4, concentration for 50% growth inhibition: 10 nM
Estimate against measurement, compound 4: 7.0-fold (0.85 log units) above, outside the stated range (below it).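

In this assay, bromo in place of nitro on an aromatic carbon of the core shared by compound 2 and compound 4 gives an 8.0-fold lower number from compound 2 to compound 4 (0.90 log units; beyond the scatter). The size of this step does not carry over between the two cores: the same change on two cores in this assay, a 1.8-fold lower number (0.26 log units; within the scatter) from compound 3 to compound 1 and an 8.0-fold lower number (0.90 log units; beyond the scatter) from compound 2 to compound 4, 4.4-fold (0.65 log units) apart, beyond the scatter of two such steps A single pair on each core shows that the step seen on one core cannot be taken as the size on the other, but it gives no reason for the gap and no rule for any further core.

Still open, on these data alone, is what bromo would do in place of the nitro that remains on the aromatic ring of the ketone arm in compound 4. Also open, as far as these compounds go, is how an amine or a carboxylic acid would compare with bromo and nitro at the changed position.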